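The source may report more compounds than this note shows. Statements on the series, on what has been measured and on what is new or still open speak of the compounds shown alone.

Measured so far:
compound 1, `CC(C)(C)c1cc(NC(=O)Nc2cc(C(F)(F)F)cc(C(F)(F)F)c2)n(-c2ccc(F)cc2)n1`: 0.4 degrees C
compound 2, `CC(C)(C)c1cc(NC(=O)Nc2cc(C(F)(F)F)cc(C(F)(F)F)c2)n(C(C)(C)C)n1`: 0.5 degrees C
compound 3, `CC(C)(C)c1cc(NC(=O)Nc2cc(F)cc(F)c2)n(-c2ccc(F)cc2)n1`: 1.9 degrees C

All three numbers come from an assay on isolated protein for inhibition of Ephrin type-A receptor 2 (Homo sapiens), read by thermal shift assay, tested at 10 uM; on this read-out lower numbers stand for weaker stabilisation of the target and higher numbers for stronger stabilisation of the target against heat. Compound 1 and compound 2 differ in one place: tert-butyl in place of 4-fluorophenyl on an aromatic nitrogen. The step it made, a number 0.10 degrees C higher from compound 1 to compound 2 (within the scatter), lies within the scatter, so the two numbers do not separate. Compound 3 carries a different core; how the core of compound 3 differs from the core of compound 1 is not broken down here. In this assay compound 3 gives the highest of the three numbers, and its distance to compound 2 as well as to compound 1 is beyond the scatter.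

Compound 4, `CC(C)(C)c1cc(NC(=O)Nc2cc(F)cc(F)c2)n(C(C)(C)C)n1`, is not yet measured. It differs from compound 3 in one place: tert-butyl in place of 4-fluorophenyl on an aromatic nitrogen. For the measured compounds named here, this is the same change as the one from compound 1 to compound 2, at the same place around the shared five-membered ring. Because a number 0.10 degrees C higher from compound 1 to compound 2 (within the scatter) was flat, the step from compound 3 to compound 4 is expected to be small, about no change at the digits printed from compound 3 to compound 4 (within the scatter). Compound 4 is therefore estimated at 1.9 degrees C, with a likely range from 0.8 degrees C to 3 degrees C.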

Compound 4, shift of the target's melting temperature: 0 degrees C
Compound 4: the middle estimate sits 1.9 degrees C above what was measured; measured number below the stated range.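

In this assay, tert-butyl in place of 4-fluorophenyl on an aromatic nitrogen does not give the same step on the two cores: the same change on two cores in this assay, a number 0.10 degrees C higher (within the scatter) from compound 1 to compound 2 and a number 1.9 degrees C lower (beyond the scatter) from compound 3 to compound 4, 2.0 degrees C apart, beyond the scatter of two such steps

The change gives a number 1.9 degrees C lower from compound 3 to compound 4 (beyond the scatter), so the flat step seen on the core of compound 1 is no guide to the size of the step on the other core. Two cores are too few for a rule across the series, and these numbers do not show which difference between the cores goes with the different steps.

Still open, on these data alone, is how a methyl group, a longer chain or a phenyl ring without fluorine on that aromatic nitrogen would read in this assay, on either core. Also open, as far as these compounds go, is whether a single trifluoromethyl group or a nitrile on the other aromatic ring would give a core on which the change stays flat or one on which it costs stabilisation.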